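Moving the nitro group in glycosylated aroylhydrazones

The source may hold more compounds than are shown below. What is called first, only, known or untested is meant among the compounds shown, and "the series" means these compounds.

Measured compounds:
compound 1 `O=C(N/N=C/c1ccc(F)cc1)c1ccc(O[C@@H]2O[C@H](CO)[C@@H](O)[C@H](O)[C@H]2O)cc1`: 9.91%
compound 2 `COc1ccc(/C=N/NC(=O)c2ccc(O[C@@H]3O[C@H](CO)[C@@H](O)[C@H](O)[C@H]3O)cc2)cc1`: 11.3%
compound 3 `O=C(N/N=C/c1cccc([N+](=O)[O-])c1)c1ccc(O[C@@H]2O[C@H](CO)[C@@H](O)[C@H](O)[C@H]2O)cc1`: 6.23%

In a functional assay on MDA-MB-231 cells (Homo sapiens) for inhibition, read by MTT assay, with a stated time of 24 h, tested at 100 uM (on this read-out lower numbers stand for less inhibition and higher numbers for more inhibition at the one concentration tested (going by the name of the read-out)), the three compounds, which share one core and differ only in the aryl group on the carbon with a double bond to nitrogen, all give small numbers. Compound 3 gives the lowest of the three, yet the steps leading to it are within the scatter: a number 3.7 percentage points lower from compound 1 to compound 3 (within the scatter) and a number 5.1 percentage points lower from compound 2 to compound 3 (within the scatter), as is a number 1.4 percentage points higher from compound 1 to compound 2 (within the scatter). Compound 4 `O=C(N/N=C/c1ccc([N+](=O)[O-])cc1)c1ccc(O[C@@H]2O[C@H](CO)[C@@H](O)[C@H](O)[C@H]2O)cc1` differs from compound 3 by 4-nitrophenyl in place of 3-nitrophenyl on a carbon with a double bond to nitrogen. For the measured compounds named here, no measured step makes this exact exchange, but the exchanges of whole aryl groups between compound 1, compound 2 and compound 3 all stayed within the scatter, so no step beyond the scatter is expected in this assay. Compound 4 is therefore estimated at 8.5%, within 2% to 17%. This estimate means a number 2.3 percentage points higher from compound 3 to compound 4 (within the scatter), expected to stay within the scatter.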

Compound 4, a percentage reported as inhibition, at one concentration (the size of the read-out at that concentration, not a potency): 7.12%
The estimate for compound 4 lay 1.4 percentage points above the measured number, and the stated range covers the measured number.
By their numbers in this assay, from the lowest: compounds 3, 4, 1 and 2 (each within the scatter of the next).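

In this assay, moving the nitro group on the aryl ring gives a number 0.9 percentage points higher from compound 3 to compound 4 (within the scatter). The 4-nitrophenyl compound also stays close to the other two, with a number 4.2 percentage points lower from compound 2 to compound 4 (within the scatter) and a number 2.8 percentage points lower from compound 1 to compound 4 (within the scatter), so neither the nitro group's place nor nitro in exchange for methoxy or fluoro separates these compounds. No evidence here bears on why these numbers lie so close. The compounds shown leave open whether an amine or a carboxylic acid on this aryl ring would give a step beyond the scatter.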